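A few compounds are considered here, and "the series" means these few. Any claim that something is new, unique, unknown or untested is made for them only; others in the source may bear on it.

Of the compounds shown here, three of this small set have been measured. Compound 1 `CCc1oc2cc(OC)ccc2c1C(=O)c1ccc(OC)cc1`, compound 2 `CCc1cc2cc(OC)cc(C(=O)c3ccc(O)cc3)c2o1` and compound 3 `CCc1cc2cc(O)cc(C(=O)c3ccc(O)cc3)c2o1` were tested in an assay for inhibition of solute carrier family 22 member 12 (Homo sapiens), read by scintillation counting, with a stated time of 60 min, tested at 50 uM; a lower number here means less inhibition, a higher number more inhibition at the concentration tested (going by the name of the read-out). Compound 1 gives 6.2%, compound 2 gives 60% and compound 3 gives 41%, so compound 1 stands lowest of the three. The difference between the core of compound 1 and the core of compound 2 is not broken down here.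

Compound 2 and compound 3 differ in one place: hydrogen in place of methyl on an oxygen on an aromatic ring. This change made the step of a number 19 percentage points lower from compound 2 to compound 3 (beyond the scatter).

Compound 4 `CCc1oc2cc(OC)ccc2c1C(=O)c1ccc(O)cc1` has not yet been measured in this assay. It differs from compound 1 in one place: hydrogen in place of methyl on an oxygen on an aromatic ring. The surroundings of that place read the same as for the step between compound 2 and compound 3, so this is the same change, seen here for the second time.

Within the data shown here, only one measured instance of this change exists, and it points downward. Compound 1, however, already lies near the bottom of the scale, so a drop of the size seen from compound 2 to compound 3 cannot be repeated in full. Among the measured compounds shown here, the expectation for compound 4 is therefore a number that stays low, with the step of a number 5.8 percentage points higher from compound 1 to compound 4 (within the scatter), resting on the one observed step of a number 19 percentage points lower from compound 2 to compound 3 (beyond the scatter) and on the low starting value of compound 1, 6.2%. Compound 4 is estimated at 12%, somewhere between -5% and 40%.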

Compound 4, a percentage reported as inhibition, at one concentration (the size of the read-out at that concentration, not a potency): 92.7%
The estimate for compound 4 lay 80.7 percentage points below the measured number; the whole stated range lies below it.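

In this assay, the change from methoxy to hydroxy on the core of compound 1 gives a number 86.5 percentage points higher from compound 1 to compound 4 (beyond the scatter), so a compound near the bottom of the scale moves close to its top. The same small change therefore does not carry a fixed effect from one core to another in this series, as its direction and size both differ between the two cores: the same change on two cores in this assay, a number 19 percentage points lower (beyond the scatter) from compound 2 to compound 3 and a number 86.5 percentage points higher (beyond the scatter) from compound 1 to compound 4, 105.5 percentage points apart, beyond the scatter of two such steps. Among these compounds, this shows that a step measured on one core was a poor guide to the step on the other, but it does not explain the difference, and with only two pairs it gives no rule for a third core; each step also rests on a reading at a single concentration, which is not a potency.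

The compounds shown leave open how other groups in the same place on the core of compound 4 would read, for instance an amine, a carboxylic acid or a longer ether such as ethoxy. They also leave open whether the ethyl chain on the core of compound 4 contributes to its high reading, which a longer chain such as propyl could begin to test.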